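Removing the chloro group from compound 3

A few compounds are considered here, and "the series" means these few. Any claim that something is new, unique, unknown or untested is made for them only; others in the source may bear on it.

Measured in a functional assay on G55T2 cells (Homo sapiens) for antiproliferative activity, read by WST assay, with a stated time of 72 h; a higher number here means a weaker inhibitor, a lower number a stronger inhibitor:
compound 1 `O=C(CCN(Cc1ccc(C(=O)NO)cc1)C(=O)c1ccccc1)NCc1ccccc1`: 5940 nM
compound 2 `Cc1ccc(CNC(=O)CCN(Cc2ccc(C(=O)NO)cc2)C(=O)c2ccc(N(C)C)cc2)cc1`: 430 nM
compound 3 `CN(C)c1ccc(C(=O)N(CCC(=O)NCc2ccc(Cl)cc2)Cc2ccc(C(=O)NO)cc2)cc1`: 460 nM

Compound 3, at 460 nM, lies within the scatter of compound 2 and clearly below compound 1 on these numbers. Compound 4 `CN(C)c1ccc(C(=O)N(CCC(=O)NCc2ccccc2)Cc2ccc(C(=O)NO)cc2)cc1` departs from compound 3 in one place: hydrogen in place of chloro on an aromatic carbon. Going by the values given here, the only measured step at that place is a 1.1-fold higher number from compound 2 to compound 3 (0.03 log units; within the scatter), with chloro in place of methyl, and it stays within the scatter. Among the compounds with values here, no measured step sets hydrogen against either group, so the evidence is thin. In this assay the expected step, a 1.1-fold higher number from compound 3 to compound 4 (0.04 log units; within the scatter), is no larger than the scatter. Compound 4 is estimated at 500 nM, with an expected range of 220 nM to 1200 nM.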

Compound 4, half-maximal inhibitory concentration: 1150 nM
Compound 4: middle estimate off by 2.3-fold (0.36 log units), on the low side; the measured number falls inside the stated range.
By their numbers in this assay, from the lowest: compounds 2 and 3 (each within the scatter of the next); then compound 4; then compound 1.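

In this assay, the group on this aromatic carbon proves to matter: in a 2.5-fold higher number from compound 3 to compound 4 (0.40 log units; beyond the scatter) and in a 2.7-fold higher number from compound 2 to compound 4 (0.43 log units; beyond the scatter), hydrogen gives a weaker inhibitor than chloro or methyl, which the earlier step between those two groups could not show. With hydrogen at this carbon, dimethylamino in place of hydrogen elsewhere still gives a 5.2-fold lower number from compound 1 to compound 4 (0.71 log units; beyond the scatter). No measurement shown offers a reason for these steps.

On these data alone, whether fluoro, methoxy or a carboxylic acid at this carbon would match chloro and methyl remains open. So does whether chloro would give a similar step without the dimethylamino group.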